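Swapping Trifluorophenyl for Fluorophenyl on the Amide Nitrogen

This account rests on a few compounds, and the source may have more. Where it says the series, first, only, none or still open, it means among the compounds named here.

Compound 2 `CC(C)n1ncc2c(C(=O)Nc3c(F)cc(F)cc3F)cc(-c3cccs3)nc21` was examined in an ADME assay on LLC-MK2 cells (Macaca mulatta) for cytotoxicity, read by spectrophotometry and crystal violet staining, with a stated time of 4 days; on this read-out lower numbers stand for higher toxicity in this test and higher numbers for lower toxicity in this test. In this assay compound 2 reaches only a limit, > 200000 nM, so no number is known for it. Compound 1 `CC(C)n1ccc2c(C(=O)Nc3ccc(F)cc3)cc(-c3cccs3)nc21` likewise stops at a limit in this assay, giving > 200000 nM. Only compound 3 `CC(C)n1ncc2c(C(=O)Nc3ccccn3)cc(-c3ccccc3)nc21` yields a number in this assay, where compound 3 gives 12500 nM. The results thus gather at the limit of > 200000 nM in this assay, at which 2 of the 3 values shown sit, and compound 2 stands there rather than at a measured point.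

Compound 4 `CC(C)n1ncc2c(C(=O)Nc3ccc(F)cc3)cc(-c3cccs3)nc21` differs from compound 2 in one place: 4-fluorophenyl in place of 2,4,6-trifluorophenyl on an amide-type nitrogen. Within the data shown here, no step between two measured compounds is available to calibrate such a change. Compound 1 also carries a 4-fluorophenyl on its amide-type nitrogen, on a different core, and stops at its limit. Across this step the author expects no shift beyond the usual scatter. The expected change is a number no higher from compound 2 to compound 4 (the limit leaves the size open). For compound 4 the estimate is 200000 nM, within 40000 nM to 200000 nM, most likely again reported only as a limit.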

Compound 4, half-maximal cytotoxic concentration: > 200000 nM
Compound 4 gave a limit, no number (the forecaster's own chance of this, stated with the estimate: 70%); the middle value lies on the limit itself.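

Compound 2 and compound 4 both end at a limit in this assay, and no step can be read between them. The compounds shown leave open whether 4-fluorophenyl and 2,4,6-trifluorophenyl on the amide-type nitrogen differ at all in this read-out, with the values gathered at one point: the limit of > 200000 nM in this assay, at which 3 of the 4 values shown sit.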